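Compound 4: a Shorter Arm on the Ring Nitrogen

The compounds below may be only part of what the source reports. "The series", "measured", "known", "first", "only" and "open" are said of these compounds alone.

Compound 1 `CCOC(=O)C1=Cc2ccccc2OC1(OCc1cn(CC(=O)Nc2ccc(C)cc2)nn1)C(F)(F)F` in a functional assay on DU-145 cells (Homo sapiens) for inhibition, read by MTT assay, with a stated time of 24 h (on this read-out lower numbers stand for stronger inhibition and higher numbers for weaker inhibition), gives > 150000 nM, a limit of the assay rather than a number.
Compound 2 `CCOC(=O)C1=Cc2ccccc2OC1(OCc1cn(CC(=O)Nc2ccc(OC)cc2)nn1)C(F)(F)F` in this assay gives 32700 nM.
Compound 3 `CCOC(=O)C1=Cc2ccccc2OC1(OCc1cn(CC(=O)Nc2ccccc2Br)nn1)C(F)(F)F` in this assay gives > 150000 nM, again a limit of the assay.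

Compound 3 thus sits at the limit where two of the three values stand (the limit of > 150000 nM in this assay, at which 2 of the 3 values shown sit); only compound 2 returns a number. The change to compound 4 `CCOC(=O)C1=Cc2ccccc2OC1(OCc1cn(-c2ccc(C)cc2)nn1)C(F)(F)F` is 4-methylphenyl in place of ((2-bromophenyl)carbamoyl)methyl on an aromatic nitrogen. The measured steps that touch compound 3 are a step that the two limits leave unreadable from compound 1 to compound 3 and an at least 4.5-fold higher number from compound 2 to compound 3 (0.66 log units; beyond the scatter), and both concern the group on the amide-type nitrogen, a nitrogen that compound 4 no longer carries. Going by the values given here, no measured step alters the group on the aromatic nitrogen, so none sizes this change directly. The only sign that the shared core can register a number comes from compound 2. The step from compound 3 to compound 4 is expected to be an at least 1.5-fold lower number from compound 3 to compound 4 (0.17 log units; that floor lies within the scatter). Compound 4 is estimated at 100000 nM, with a range from 30000 nM to 300000 nM, and it is expected that this assay may well report only a limit once more.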

Compound 4, half-maximal inhibitory concentration: 30200 nM
Estimate against measurement, compound 4: 3.3-fold (0.52 log units) above; low and high end bracket the measured number.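

Going by these compounds alone, the group on the aromatic nitrogen of the five-membered ring, untouched by the earlier steps, now proves open to change with a readable result in this assay: 4-methylphenyl in place of the longer arms gives an at least 4.9-fold lower number from compound 3 to compound 4 (0.69 log units; beyond the scatter) and an at least 4.9-fold lower number from compound 1 to compound 4 (0.69 log units; beyond the scatter). Against the only earlier compound with a number, the same kind of change gives a 1.1-fold lower number from compound 2 to compound 4 (0.03 log units; within the scatter). The shared core therefore returns a number in this assay without the carbamoylmethyl arm, its carbonyl or the amide hydrogen, whereas with that arm the result varies with the aryl group on the amide-type nitrogen.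

As far as these compounds go, whether 4-methylphenyl itself matters stays open, as no plain phenyl, benzyl or short alkyl chain on this nitrogen stands beside it. The true size of the steps from compound 1 and compound 3 also stays open, as each starts from a limit: the limit of > 150000 nM in this assay, at which 2 of the 4 values shown sit.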